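Aryl for benzyl on the ring amine of compound 2

The source may hold more compounds than are shown below. What is called first, only, known or untested is meant among the compounds shown, and "the series" means these compounds.

compound 1: `COc1ccc(-c2cnc3nc(N)nc(N4CCC(C)CC4)c3n2)cc1OC` — 800 nM
compound 2: `COc1ccc(-c2cnc3nc(N)nc(N4CCN(Cc5ccccc5F)CC4)c3n2)cc1OC` — 700 nM

Of the compounds shown here, two have been measured in a functional assay on cells (T-cell, Homo sapiens) for inhibition; on this read-out lower numbers stand for stronger inhibition and higher numbers for weaker inhibition. Compound 1 `COc1ccc(-c2cnc3nc(N)nc(N4CCC(C)CC4)c3n2)cc1OC` carries a 4-methylpiperidine on the shared core, while compound 2 `COc1ccc(-c2cnc3nc(N)nc(N4CCN(Cc5ccccc5F)CC4)c3n2)cc1OC` carries a piperazine whose second nitrogen bears a 2-fluorobenzyl group. In this assay compound 1 gives 800 nM, and compound 2 gives 700 nM. The gap between these two numbers lies within the scatter of repeated measurement, so compound 2 cannot be told apart from compound 1 on this read-out; the two stand together.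

Compound 3 `COc1ccc(-c2cnc3nc(N)nc(N4CCN(c5ccc(F)cc5)CC4)c3n2)cc1OC` has not yet been measured. It differs from compound 2 in one place: 4-fluorophenyl in place of 2-fluorobenzyl on an amine nitrogen in a ring. Among the measured compounds shown here, no measured pair in the set shows this kind of change, so there is no step to lean on.

Given that the two measured compounds gave alike numbers despite different groups at this position, the step of a 1.3-fold higher number from compound 2 to compound 3 (0.11 log units; within the scatter) is expected to be small, with no direction beyond the scatter. Compound 3 is estimated to give 900 nM, with a range from 300 nM to 2700 nM.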

Compound 3, half-maximal inhibitory concentration: 100 nM
Compound 3: the middle estimate sits 9.0-fold (0.95 log units) above what was measured; the whole stated range lies above it.
By their numbers in this assay, from the lowest: compound 3; then compounds 2 and 1 (each within the scatter of the next).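

In this assay, among the compounds shown here, putting 4-fluorophenyl in place of 2-fluorobenzyl on the amine nitrogen of the ring gives a 7.0-fold lower number from compound 2 to compound 3 (0.85 log units; beyond the scatter), a step beyond the scatter, so this position does respond to what the nitrogen carries, which the earlier compounds alone did not show. The response comes from a small change: both groups hold a fluorine on a six-membered aromatic ring of carbon only, and neither has a hydrogen-bond donor, a hydrogen-bond acceptor or a net charge, yet the two do not read alike. No measurement at hand bears on why the number falls.

The step changes two things at once, benzyl to phenyl and the place of the fluorine on the aromatic ring, and the compounds shown leave open which of these carries the difference. A 2-fluorophenyl or a 4-fluorobenzyl group on the same nitrogen would separate the two, and a plain phenyl would show what the fluorine itself contributes.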